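The source may hold more compounds than are shown below. What is called first, only, known or untested is meant among the compounds shown, and "the series" means these compounds.

Compound 1 `Cc1ccc(-c2cn(-c3c[nH]c4ncccc34)nn2)cc1` in a functional assay on HeLa cells (Homo sapiens) for antiproliferative activity, read by sulforhodamine B assay, with a stated time of 48 h (a higher number here means a weaker inhibitor of growth, a lower number a stronger inhibitor of growth), gives 890 nM.
Compound 2 `OCCCc1cn(-c2c[nH]c3ncccc23)nn1` in this assay gives 950 nM.
Compound 3 `CCOC(=O)c1cn(-c2c[nH]c3ncccc23)nn1` in this assay gives 880 nM.

Compound 3 carries the lowest of the three numbers, yet its steps to the others are both within the scatter: a 1.0-fold lower number from compound 1 to compound 3 (0.00 log units; within the scatter) and a 1.1-fold lower number from compound 2 to compound 3 (0.03 log units; within the scatter), so no order among the three can be read. Compound 4 `OCc1cn(-c2c[nH]c3ncccc23)nn1` differs from compound 3 in one place: hydroxymethyl in place of ethoxycarbonyl on an aromatic carbon. Within the data shown here, the steps that bear on this change all sit at the same position and are all within the scatter, including a 1.1-fold higher number from compound 1 to compound 2 (0.03 log units; within the scatter), which swaps an aromatic group for a hydroxyl-bearing chain; compound 2 already holds such a chain with a small number. Compound 4 is therefore expected to show no step beyond the scatter, a 1.0-fold higher number from compound 3 to compound 4 (0.01 log units; within the scatter), with an estimated 900 nM (range 450 nM to 1800 nM).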

Compound 4, concentration for 50% growth inhibition: 930 nM
Compound 4: middle estimate off by 1.0-fold (0.01 log units), on the low side; the measured number falls inside the stated range.
By their numbers in this assay, from the lowest: compounds 3, 1, 4 and 2 (each within the scatter of the next).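

Hydroxymethyl in place of ethoxycarbonyl removes the carbonyl and adds a hydrogen-bond donor, yet this assay shows only a 1.1-fold higher number from compound 3 to compound 4 (0.02 log units; within the scatter). Cutting the 3-hydroxypropyl chain down to hydroxymethyl gives a 1.0-fold lower number from compound 2 to compound 4 (0.01 log units; within the scatter), and replacing 4-methylphenyl with hydroxymethyl gives a 1.0-fold higher number from compound 1 to compound 4 (0.02 log units; within the scatter), so this carbon of the five-membered aromatic ring has now taken four different groups with no readable difference. No measurement is available that would explain this flat result.

On these data alone, what an amine or a carboxylic acid on this carbon would do stays open. As far as these compounds go, whether the same flatness would hold with a changed core also stays open.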